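The source may hold more compounds than are shown below. What is called first, only, known or untested is meant among the compounds shown, and "the series" means these compounds.

Compound 1 `CC1(C)C(=O)Nc2nc(-n3nc(Cc4ccccc4F)c4cc(Cl)ccc43)nc(N)c21` shows the highest number of the three compounds measured in an assay on CHO cells for activation of soluble guanylate cyclase alpha1/beta1 complex (Homo sapiens), read by cGMP accumulation; a lower number here means that less compound is needed, a higher number that more compound is needed for the effect: compound 1 gives 18000 nM. Compound 2 `CC1(C)C(=O)Nc2nc(-n3nc(Cc4ccccc4F)c4ccccc43)nc(N)c21`, differing only by hydrogen in place of chloro on an aromatic carbon, gives 3000 nM; that single change gave a 6.0-fold lower number from compound 1 to compound 2 (0.78 log units; beyond the scatter). Within the data shown here, compound 3 `COC(=O)Nc1c(N)nc(-n2nc(Cc3c(F)ccc(F)c3F)c3cc(Cl)ccc32)nc1N`, built on a different core, gives 670 nM, and no single step connects it to compound 1. Compound 4 `CCCCc1nn(-c2nc(N)c3c(n2)NC(=O)C3(C)C)c2ccc(Cl)cc12` keeps the chloro and the core of compound 1 but carries propyl in place of 2-fluorophenyl on a saturated chain carbon bound to an aromatic carbon. Among the measured compounds shown here, none of the measured steps touches this part of the molecule, so no direction of change can be read from them. The estimate for compound 4 is 25000 nM, with a range from 6000 nM to 100000 nM. That expectation amounts to a 1.4-fold higher number from compound 1 to compound 4 (0.14 log units; within the scatter).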

Compound 4, half-maximal effective concentration: 47000 nM
Compound 4: middle estimate off by 1.9-fold (0.27 log units), on the low side, within the range that was stated.
By their numbers in this assay, from the lowest: compound 3; then compound 2; then compound 1; then compound 4.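

Swapping 2-fluorobenzyl for butyl, with propyl in place of 2-fluorophenyl on a saturated chain carbon bound to an aromatic carbon, gave a 2.6-fold higher number from compound 1 to compound 4 (0.42 log units; beyond the scatter) in this one pair. This first measured change at this position shows that a plain chain without the aromatic ring calls for more compound, though only modestly. No measurement shown gives a reason for this rise. From the compounds shown here alone, whether an amine or a carboxylic acid on the chain would lower the number remains open. So does whether butyl would have a similar effect on compound 2, which carries hydrogen instead of chloro.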